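A few compounds are considered here, and "the series" means these few. Any claim that something is new, unique, unknown or untested is made for them only; others in the source may bear on it.

Compound 1 `CCN(CC)c1ccc2cc(C(=O)c3ccc(N4CCN(S(=O)(=O)c5ccc([N+](=O)[O-])cc5)CC4)cc3)oc2c1`: in a functional assay on MCF7 cells (Homo sapiens) for cytotoxicity, read by MTT assay, with a stated time of 48 h (a higher number here means a weaker inhibitor, a lower number a stronger inhibitor), compound 1 gives a limit of > 40000 nM.
Compound 2 `CCN(CC)c1ccc2cc(C(=O)c3ccc(N4CCN(S(=O)(=O)c5ccc(F)cc5)CC4)cc3)oc2c1`: in this assay compound 2 gives 21700 nM.

For the measured compounds named here, compound 2 holds the only number measured; the other result is a limit, (the limit of > 40000 nM in this assay, at which 1 of the 2 values shown sits). Going by the values given here, the single measured step, an at least 1.8-fold lower number from compound 1 to compound 2 (0.26 log units; that floor lies within the scatter), swaps one substituent on an aromatic carbon. Compound 3 `CCN(CC)c1ccc2cc(C(=O)c3ccc(N4CCN(C(C)=O)CC4)cc3)oc2c1` differs from compound 2 by acetyl in place of (4-fluorophenyl)sulfonyl on an amine nitrogen in a ring. Among the compounds with values here, no measured step resembles that change, so there is no basis to expect a shift beyond the scatter in this assay. Compound 3 is therefore estimated at 25000 nM, within a range from 8000 nM to 80000 nM. The step of a 1.2-fold higher number from compound 2 to compound 3 (0.06 log units; within the scatter) is thus expected to be small.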

Compound 3, half-maximal inhibitory concentration: 16200 nM
Beside the measured number, compound 3's estimate is 1.5-fold (0.19 log units) above it; the range from low to high includes it.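

At this ring nitrogen, (4-fluorophenyl)sulfonyl can be replaced by acetyl, which has no ring, with no change beyond the scatter in this assay: a 1.3-fold lower number from compound 2 to compound 3 (0.13 log units; within the scatter). Replacing (4-nitrophenyl)sulfonyl with acetyl at the same nitrogen gives the only step shown beyond the scatter, an at least 2.4-fold lower number from compound 1 to compound 3 (0.39 log units; beyond the scatter). That step is only a floor, since compound 1 gives a limit and not a number: the limit of > 40000 nM in this assay, at which 1 of the 3 values shown sits.

As far as these compounds go, whether a longer acyl chain or a basic amine on this nitrogen would move the number beyond the scatter from compound 3 remains open. The shared core is the same in all three compounds, so what it contributes is also unknown.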